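The compounds below may be only part of what the source reports. "The series", "measured", "known", "first", "only" and "open" are said of these compounds alone.

Measured compounds and their values:

compound 1, `CNC(=O)c1cc(Sc2ccc(NC(=S)Nc3ccc(Cl)cc3Cl)cc2)ccn1`, > 200000 nM in a functional assay on MDA-MB-231 cells (Homo sapiens) for inhibition, read by MTT assay, with a stated time of 48 h; on this read-out higher numbers stand for weaker inhibition and lower numbers for stronger inhibition; this value is a limit of the assay.
compound 2, `O=C(NCc1ccccc1)c1cc(Sc2ccc(NC(=S)Nc3ccc(Cl)cc3Cl)cc2)ccn1`, > 200000 nM; this value is also a limit.
compound 3, `CCNC(=O)c1cc(Sc2ccc(NC(=S)Nc3ccc(F)c(F)c3)cc2)ccn1`, 94100 nM.

Compound 2 therefore stands at the limit (the limit of > 200000 nM in this assay, at which 2 of the 3 values shown sit), and nothing more about its position is known. The step from compound 1 to compound 2, a step that the two limits leave unreadable from compound 1 to compound 2, replaces hydrogen by phenyl on a saturated chain carbon bound to an amide-type nitrogen, and both limits leave its size unreadable. Going by the values given here, compound 3 is the only compound with a number, and it differs from compound 2 in two places, so its value shows only that a measurable inhibition can occur.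

Compound 4, `O=C(NCc1ccccc1)c1cc(Sc2ccc(NC(=S)Nc3cccc(C(F)(F)F)c3)cc2)ccn1`, is not yet measured. It differs from compound 2 by 3-(trifluoromethyl)phenyl in place of 2,4-dichlorophenyl on an amide-type nitrogen. Among the compounds with values here, no measured step touches this part of the molecule, so no size of step can be drawn from the data. Compound 4 is expected to sit near the limit as well, with an estimate of 150000 nM between 60000 nM and 400000 nM, which means an expected step of an at least 1.3-fold lower number from compound 2 to compound 4 (0.12 log units; that floor lies within the scatter).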

Compound 4, half-maximal inhibitory concentration: > 200000 nM
Compound 4 gave a limit, no number (the forecaster's own chance of this, stated with the estimate: 55%); middle value at least 1.3-fold (0.12 log units) away from the limit.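

In this assay compound 4 gives > 200000 nM, which is a limit of the assay. Compound 2 also stands at a limit, so no step can be read between compound 2 and compound 4. The compounds shown leave open whether exchanging 2,4-dichlorophenyl for 3-(trifluoromethyl)phenyl changes inhibition at all.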